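This account rests on a few compounds, and the source may have more. Where it says the series, first, only, none or still open, it means among the compounds named here.

Working notes on the series. Among the measured compounds shown here, in a functional assay on KB cells (Homo sapiens) for antiproliferative activity (a higher number here means a weaker inhibitor, a lower number a stronger inhibitor), compound 2 (`COc1ccc(S(=O)(=O)N2CCc3cccc(Nc4ccc(F)c(F)c4)c32)cc1`) gives 412 nM, the lower of the two numbers so far, while compound 1 (`COc1ccc(S(=O)(=O)N2CCc3cccc(Nc4ccc(Cl)cc4)c32)cc1`) gives 1100 nM.

Next in line is compound 3 (`COc1ccc(S(=O)(=O)N2CCc3cccc(Nc4ccc([N+](=O)[O-])cc4)c32)cc1`), with 4-nitrophenyl in place of 3,4-difluorophenyl on a nitrogen on an aromatic ring.

For the measured compounds named here, only one measured step bears on this place: a 2.7-fold lower number from compound 1 to compound 2 (0.43 log units; beyond the scatter), a modest step beyond the scatter, on going from 4-chlorophenyl to 3,4-difluorophenyl. Going by the values given here, a single step gives a rough size but no trend, and no measured compound carries 4-nitrophenyl. The aryl groups exchanged so far have therefore moved this assay only modestly, and a step of about that size is the working assumption. The direction is weakly held, leaning towards a higher number, since compound 2 is the lower of the two measured compounds at 412 nM.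

The expected change is a 2.2-fold higher number from compound 2 to compound 3 (0.34 log units; beyond the scatter), with low confidence in its direction. For compound 3 the estimated value is 900 nM, with an expected range of 250 nM to 3000 nM.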

Compound 3, half-maximal inhibitory concentration: 101 nM
Compound 3: the middle estimate sits 8.9-fold (0.95 log units) above what was measured, outside the stated range (below it).
By their numbers in this assay, from the lowest: compound 3; then compound 2; then compound 1.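

In this assay, among the compounds shown here, the aryl group on the nitrogen proves to be a place where a single exchange can produce a large change, not only the modest one seen so far. 4-Nitrophenyl in place of 3,4-difluorophenyl gives a 4.1-fold lower number from compound 2 to compound 3 (0.61 log units; beyond the scatter), and nitro in place of chloro on an aromatic carbon gives an 11-fold lower number from compound 1 to compound 3 (1.04 log units; beyond the scatter), the only step in the set printed as large, which makes compound 3 the most potent of the three, with both of its steps beyond the scatter. Nothing available on these compounds accounts for these steps, so the result stands as an observation on three aryl groups only.

Three aryl groups cannot show whether the low number belongs to nitro itself or would also be reached with a nitrile, a carboxylic acid, an amine or a trifluoromethyl group at the same place on the phenyl ring. On these data alone, it also remains open whether the gain from 4-nitrophenyl would hold if the methoxy group on the sulfonyl aryl ring were replaced by, for example, an ethoxy group or a hydrogen.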